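Cyano in Place of Methoxy: Expected Tolerance of Compound 4

The compounds below may be only part of what the source reports. "The series", "measured", "known", "first", "only" and "open" are said of these compounds alone.

Measured compounds:
compound 1 `COc1ccc(N/N=C2\C(=O)N(Cc3cn(O[C@@H]4O[C@H](CC(C)=O)[C@@H](OC(C)=O)[C@H](OC(C)=O)[C@H]4OC(C)=O)nn3)c3ccccc32)cc1` with 95300 nM
compound 2 `CC(=O)C[C@H]1O[C@@H](On2cc(CN3C(=O)/C(=N\Nc4ccc(C#N)cc4)c4ccccc43)nn2)[C@H](OC(C)=O)[C@@H](OC(C)=O)[C@@H]1OC(C)=O` with 75400 nM
compound 3 `COc1ccc(N/N=C2\C(=O)N(Cc3cn(O[C@@H]4O[C@H](CO)[C@H](O)[C@H](O)[C@H]4O)nn3)c3ccccc32)cc1` with 76200 nM

Of the compounds shown here, three have been measured in an ADME assay on Vero cells (Chlorocebus sabaeus) for cytotoxicity, read by fluorescence and resazurin assay, with a stated time of 3 days; a higher number here means that more compound is tolerated, a lower number that less compound is tolerated. Compound 1 gives 95300 nM, compound 2 gives 75400 nM, and compound 3 gives 76200 nM. All three numbers sit close together, and none of the gaps between them is beyond the usual scatter of this kind of measurement.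

Compound 1 and compound 2 differ in one place: cyano in place of methoxy on an aromatic carbon. The step this change made is a 1.3-fold lower number from compound 1 to compound 2 (0.10 log units; within the scatter), so within the scatter.

Compound 4 `N#Cc1ccc(N/N=C2\C(=O)N(Cc3cn(O[C@@H]4O[C@H](CO)[C@H](O)[C@H](O)[C@H]4O)nn3)c3ccccc32)cc1` has not yet been measured in this assay. It differs from compound 3 in one place: cyano in place of methoxy on an aromatic carbon. For the measured compounds named here, this is the same kind of change as the one between compound 1 and compound 2, at the same place. The cores of compound 3 and compound 1 differ elsewhere, but the difference between the two cores is not broken down here.

The expectation for compound 4 rests on the step from compound 1 to compound 2, which stayed within the scatter, and on the value of compound 3 as the starting point. The estimated step is a 1.2-fold lower number from compound 3 to compound 4 (0.07 log units; within the scatter), on the same scale as the earlier one. Compound 4 is therefore expected to give about 65000 nM in this assay, with a likely range from 35000 nM to 120000 nM.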

Compound 4, half-maximal cytotoxic concentration: 93700 nM
Compound 4: middle estimate off by 1.4-fold (0.16 log units), on the low side, within the range that was stated.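

In this assay, cyano in place of methoxy on the core of compound 3 gives a 1.2-fold higher number from compound 3 to compound 4 (0.09 log units; within the scatter). Set beside the earlier case on the core of compound 1, the two steps cannot be told apart: the same change on two cores in this assay, a 1.3-fold lower number (0.10 log units; within the scatter) from compound 1 to compound 2 and a 1.2-fold higher number (0.09 log units; within the scatter) from compound 3 to compound 4, 1.6-fold (0.19 log units) apart, within the scatter of two such steps. For the compounds shown here, in this series the change thus carries from one core to the other without a step beyond the scatter on either, but this rests on only two pairs, and it shows neither that the change has any real effect on tolerance in this assay nor that the core decides how the change reads out, and a change with a larger step might carry over quite differently.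

All four compounds hold either 4-methoxyphenyl or 4-cyanophenyl at this place, so the compounds shown leave open whether another group there, such as an amine or a carboxylic acid, would give a step beyond the scatter. They also leave open whether the same swap of methoxy for cyano would stay as small on a core carrying something else, such as a longer chain, in place of the parts that vary here.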